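The source may report more compounds than this note shows. Statements on the series, on what has been measured and on what is new or still open speak of the compounds shown alone.

Measured compounds in a functional assay on KB cells (Homo sapiens) for cytotoxicity; a higher number here means a weaker inhibitor, a lower number a stronger inhibitor:
- compound 1 `COc1ccc(S(=O)(=O)N2CCc3cccc(NC(=O)c4cccs4)c32)cc1` gives 47 nM
- compound 2 `COc1ccc(S(=O)(=O)N2CCc3cccc(NC(=O)c4ccc([N+](=O)[O-])cc4)c32)cc1` gives 102 nM
- compound 3 `COc1ccc(S(=O)(=O)N2CCc3cc(Br)cc(NC(=O)c4ccco4)c32)cc1` gives 89 nM

Compound 1 has the lowest of the three numbers in this assay, and compound 3 sits within the scatter of it. For the measured compounds named here, the only measured step that changes the group on the carbonyl carbon is a 2.2-fold higher number from compound 1 to compound 2 (0.34 log units; beyond the scatter), a modest move to a higher number. Compound 4 `COc1ccc(S(=O)(=O)N2CCc3cccc(NC(=O)c4ccco4)c32)cc1` differs from compound 1 in this way: furan-2-yl in place of thiophen-2-yl on a carbonyl carbon. Compound 3 carries the same furan-2-yl group, together with a bromine, and its value lies within the scatter of compound 1. Going by the values given here, no measured step exchanges thiophen-2-yl for furan-2-yl directly, so the expectation is a change of no more than the scatter. For compound 4 the estimate is 60 nM, between 30 nM and 120 nM, that is an expected step of a 1.3-fold higher number from compound 1 to compound 4 (0.11 log units; within the scatter).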

Compound 4, half-maximal inhibitory concentration: 9.6 nM
For compound 4 the middle estimate is 6.3-fold (0.80 log units) above the measured one; measured number below the stated range.
By their numbers in this assay, from the lowest: compound 4; then compounds 1, 3 and 2 (each within the scatter of the next, the first and the last beyond it).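

In this assay, the group on the carbonyl carbon matters more than the earlier step suggested: exchanging one five-membered aromatic ring for another gives a 4.9-fold lower number from compound 1 to compound 4 (0.69 log units; beyond the scatter), and replacing 4-nitrophenyl with furan-2-yl gives an 11-fold lower number from compound 2 to compound 4 (1.03 log units; beyond the scatter). The bromine also carries a large share of the picture, since hydrogen in its place on the aromatic carbon gives a 9.3-fold lower number from compound 3 to compound 4 (0.97 log units; beyond the scatter), so the earlier bromo furan value did not show what furan-2-yl alone can do. Nothing available explains these steps. Still open, as far as these compounds go, are how bromine acts alongside thiophen-2-yl, and how a pyridin-2-yl or pyrrol-2-yl ring on the carbonyl carbon would compare.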